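This account rests on a few compounds, and the source may have more. Where it says the series, first, only, none or still open, it means among the compounds named here.

Compounds measured so far:
- compound 1, `O=C(O)CC1CCCC1Cc1ccc(OCc2ccc3ccccc3n2)cc1`, 100 nM
- compound 2, `O=C(O)CCCOc1ccc(OCc2ccc3ccccc3n2)cc1`, 1200 nM
- compound 3, `CC(CCc1nnn[nH]1)Cc1ccc(OCc2ccc3ccccc3n2)cc1`, 12 nM

Of the three compounds measured in an assay on membranes from lung (Cavia porcellus) for binding affinity to cysteinyl leukotriene receptor (Homo sapiens) (a lower number here means a stronger inhibitor, a higher number a weaker inhibitor), compound 3 gives the lowest number. Its nearest neighbour is compound 1, and the step of an 8.3-fold lower number from compound 1 to compound 3 (0.92 log units; beyond the scatter) is beyond the scatter. Compound 2 lies furthest away, with a value a great deal higher than that of compound 3.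

Compound 4, `CC(CCC(=O)O)Cc1ccc(OCc2ccc3ccccc3n2)cc1`, is the next compound to be measured in this assay. It differs from compound 3 in one place: carboxy in place of 1H-tetrazol-5-yl on a saturated chain carbon, four bonds along the chain from an aromatic carbon. Among the measured compounds shown here, only one measured step bears on this change, and it does so indirectly. The step of an 8.3-fold lower number from compound 1 to compound 3 (0.92 log units; beyond the scatter) joins a change of the acidic group to a change of the chain that carries it, so it does not separate the two. For the measured compounds named here, compound 1 and compound 2 both carry a carboxy group and both give higher numbers than compound 3, which suggests that the carboxy group in compound 4 may bring a somewhat higher number than the tetrazole of compound 3, though the chain of compound 4 is the one of compound 3. The expected step is a 3.3-fold higher number from compound 3 to compound 4 (0.52 log units; beyond the scatter). Compound 4 is therefore expected to give 40 nM in this assay, within a range from 10 nM to 160 nM.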

Compound 4, inhibition constant: 43 nM
Compound 4: middle estimate off by 1.1-fold (0.03 log units), on the low side; the range from low to high includes it.
By their numbers in this assay, from the lowest: compound 3; then compound 4; then compound 1; then compound 2.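

With the chain held constant, the change in this assay now stands on its own: replacing 1H-tetrazol-5-yl with carboxy gives a 3.6-fold higher number from compound 3 to compound 4 (0.55 log units; beyond the scatter), whereas the earlier step of an 8.3-fold lower number from compound 1 to compound 3 (0.92 log units; beyond the scatter) changed the end group and the chain together. The carboxy compounds also show that the chain matters apart from the end group, since 3-carboxy-1-methylpropyl in place of 2-(carboxymethyl)cyclopentyl gives a 2.3-fold lower number from compound 1 to compound 4 (0.37 log units; beyond the scatter), and 4-carboxy-2-methylbutyl in place of 3-carboxypropoxy gives the much larger a 28-fold lower number from compound 2 to compound 4 (1.45 log units; beyond the scatter). No measurement offered here accounts for the direction or size of any of these steps.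

The compounds shown leave open whether 1H-tetrazol-5-yl would also give a lower number than carboxy on the 2-(carboxymethyl)cyclopentyl or 3-carboxypropoxy frameworks, where only the carboxy form appears. They also leave open what the chain methyl contributes on its own, how an unbranched chain or a longer chain would compare, and how another end group, such as an acyl sulfonamide or a primary amide, would behave at this position.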